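The compounds below may be only part of what the source reports. "The series", "measured", "known", "first", "only" and "open" are said of these compounds alone.

Measured compounds:
compound 1 `O=C(COCc1ccccc1)N1CCN(c2ncccc2C(F)(F)F)CC1` gives 4300 nM in a functional assay on HEK293 cells for positive allosteric modulation of metabotropic glutamate receptor 5 (Rattus norvegicus), read by fluorescence and calcium flux; a higher number here means that more compound is needed for the effect, a lower number that less compound is needed.
compound 2 `COC(=O)c1ccccc1N1CCN(C(=O)COCc2ccccc2)CC1` gives > 10000 nM in this assay; this is a limit of the assay, not a number (the limit of > 10000 nM in this assay, at which 1 of the 3 values shown sits).
compound 3 `O=C(COCc1ccccc1)N1CCN(c2ccccc2[N+](=O)[O-])CC1` gives 1800 nM in this assay.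

Of the two numbers in this assay, compound 1 has the higher one; its nearest neighbour is compound 3, whose number is lower, and the gap between these two lies beyond the scatter. Among the compounds with values here, the one measured single-point step, an at least 5.5-fold lower number from compound 2 to compound 3 (0.74 log units; beyond the scatter), concerns the nitro for methoxycarbonyl exchange on the shared core of compound 2 and says nothing about the change now at hand.

Compound 4 `N#Cc1cccnc1N1CCN(C(=O)COCc2ccccc2)CC1` differs from compound 1 by cyano in place of trifluoromethyl on an aromatic carbon. Within the data shown here, no measured step bears on this exchange; the expectation for compound 4 in this assay therefore rests on compound 1 alone. Compound 4 is expected to show a step of a 1.1-fold lower number from compound 1 to compound 4 (0.03 log units; within the scatter) that stays within the scatter. Compound 4 is accordingly estimated at 4000 nM, within 1500 nM to 12000 nM.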

Compound 4, half-maximal effective concentration: > 10000 nM
Compound 4: no number, only a limit; the forecaster's own chance of this, stated with the estimate: 25%; at least 2.5-fold (0.39 log units) between middle value and limit.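

On the core of compound 1, the aromatic carbon ortho to a large group and two atoms from the ring nitrogen does not tolerate every exchange: in this assay, cyano in place of trifluoromethyl gives an at least 2.3-fold higher number from compound 1 to compound 4 (0.36 log units; beyond the scatter). Of these two groups at this place, only trifluoromethyl gives a readable number, with compound 1 at 4300 nM. Compound 4 gives > 10000 nM, which is a limit of the assay and not a number, so the step has a lower bound only: the limit of > 10000 nM in this assay, at which 2 of the 4 values shown sit.

The compounds shown leave open how a methyl group or a chlorine atom at this place would read, and so whether trifluoromethyl is a special case. As far as these compounds go, it also remains open whether nitro and methoxycarbonyl would keep their order from compound 2 and compound 3 on the core of compound 1.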